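This account rests on a few compounds, and the source may have more. Where it says the series, first, only, none or still open, it means among the compounds named here.

Compound 1 `S=c1oc(-c2ccc3c(c2)OCCO3)nn1CN1CCN(C(c2ccccc2)c2ccccc2)CC1` and compound 2 `S=c1oc(-c2ccc3c(c2)OCCO3)nn1CN1CCN(c2ccc(Cl)cc2)CC1` share a core and were both tested in a functional assay on HeLa cells (Homo sapiens) for antiproliferative activity, read by MTT assay, with a stated time of 48 h; on this read-out higher numbers stand for weaker inhibition and lower numbers for stronger inhibition. Compound 1 gives > 50000 nM, which is a limit and not a number. Compound 2 gives > 50000 nM, which is also a limit and not a number. Compound 3 `COc1cccc(N2CCN(Cn3nc(-c4ccc5c(c4)OCCO5)oc3=S)CC2)c1` carries 3-methoxyphenyl in place of 4-chlorophenyl on an amine nitrogen in a ring. Among the measured compounds shown here, no measured step is available as a guide, so the only reference is the limit of > 50000 nM in this assay, at which 2 of the 2 values shown sit. The expected step, a number no higher from compound 2 to compound 3 (the limit leaves the size open), is none beyond the scatter in this assay. For compound 3 the estimated value is 50000 nM, with an expected range from 20000 nM to 100000 nM.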

Compound 3, half-maximal inhibitory concentration: 18000 nM
For compound 3 the middle estimate is 2.8-fold (0.44 log units) above the measured one, outside the stated range (below it).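

In this assay, the group on an amine nitrogen in a ring proves able to change the read-out: 3-methoxyphenyl in place of 4-chlorophenyl gives an at least 2.7-fold lower number from compound 2 to compound 3 (0.44 log units; beyond the scatter). Compound 3 holds the only true number among the compounds shown on the shared core. The full size of this step stays unknown because compound 2 offers only a limit as its starting point: the limit of > 50000 nM in this assay, at which 2 of the 3 values shown sit.

From the compounds shown here alone, it remains open whether the change follows the methoxy group or its place on the ring, which 4-methoxyphenyl and 3-chlorophenyl could separate. Going by these compounds, how 3-hydroxyphenyl or 3-aminophenyl would read here is also open.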